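Aryl substituent variation on a thiosemicarbazone terminus: chloro analogue

The compounds below may be only part of what the source reports. "The series", "measured", "known", "first", "only" and "open" are said of these compounds alone.

Measured compounds:
Compound 1 `CC1=CC[C@@H]([C@@](C)(O)CCCC(C)(C)NC(=S)N/N=C\c2ccccc2)CC1` gives 36500 nM in a functional assay on HT-29 cells (Homo sapiens) for cytotoxicity, read by sulforhodamine B assay; a lower number here means a stronger inhibitor of growth, a higher number a weaker inhibitor of growth.
Compound 2 `CC1=CC[C@@H]([C@@](C)(O)CCCC(C)(C)NC(=S)N/N=C\c2ccc(O)cc2)CC1` gives 31500 nM in this assay.
Compound 3 `CC1=CC[C@@H]([C@@](C)(O)CCCC(C)(C)NC(=S)N/N=C\c2cccc([N+](=O)[O-])c2)CC1` gives 57100 nM in this assay.

Compound 1 stands second highest of the three numbers. Its nearest neighbour is compound 2, reached by a 1.2-fold lower number from compound 1 to compound 2 (0.06 log units; within the scatter); its furthest is compound 3, reached by a 1.6-fold higher number from compound 1 to compound 3 (0.19 log units; within the scatter). The remaining pair shows a 1.8-fold higher number from compound 2 to compound 3 (0.26 log units; within the scatter). Among the measured compounds shown here, every step so far lies within the scatter, so the three compounds cannot be placed in any order on these numbers, and neither hydroxy nor nitro entering an aromatic carbon of the shared core has produced a detectable shift.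

Compound 4 `CC1=CC[C@@H]([C@@](C)(O)CCCC(C)(C)NC(=S)N/N=C\c2ccc(Cl)cc2)CC1` is the next member. Relative to compound 1 the change is chloro in place of hydrogen on an aromatic carbon. For the measured compounds named here, no measured step brings a chloro onto this ring; the only comparable steps are hydroxy and nitro entering an aromatic carbon, and both stayed within the scatter. On that basis the step of a 1.0-fold lower number from compound 1 to compound 4 (0.01 log units; within the scatter) is expected to remain within the scatter as well, with no direction favoured.

Compound 4 is therefore expected to give about 36000 nM, with a range from 17000 nM to 75000 nM.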

Compound 4, concentration for total growth inhibition: 22600 nM
Compound 4: the middle estimate sits 1.6-fold (0.20 log units) above what was measured, and the stated range covers the measured number.
By their numbers in this assay, from the lowest: compounds 4, 2, 1 and 3 (each within the scatter of the next, the first and the last beyond it).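

In this assay, the chloro analogue provides the first separation in the series: a 2.5-fold lower number from compound 3 to compound 4 (0.40 log units; beyond the scatter), a modest step and the only one so far beyond the scatter, with 4-chlorophenyl in place of 3-nitrophenyl changing both the group and its printed position on the ring. Chloro itself does not separate from hydrogen or hydroxy at this place, para to a large group, as a 1.6-fold lower number from compound 1 to compound 4 (0.21 log units; within the scatter) and a 1.4-fold lower number from compound 2 to compound 4 (0.14 log units; within the scatter) both stay within the scatter, so the separation rests on the pair of compound 3 and compound 4 alone. Nothing available here gives a measured basis for explaining that step.

On these data alone, whether that separation follows the identity of the group or its place on the ring stays open, and 3-chlorophenyl and 4-nitrophenyl analogues would be the direct tests. Also open, as far as these compounds go, is whether an amine or a carboxylic acid at this para position would move the number beyond the scatter from compound 1.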